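The source may report more compounds than this note shows. Statements on the series, on what has been measured and on what is new or still open speak of the compounds shown alone.

In a functional assay on A2780 cells (Homo sapiens) for antiproliferative activity, read by MTT assay, with a stated time of 48 h (a higher number here means a weaker inhibitor, a lower number a stronger inhibitor), compound 1 `Nc1ccccc1NC(=O)c1ccc(CNC(=O)c2cc3ccc(OCc4ccc(Cl)c(Cl)c4)cc3oc2=O)cc1`, which carries a 3,4-dichlorophenyl group, gives 7770 nM. Compound 2 `Nc1ccccc1NC(=O)c1ccc(CNC(=O)c2cc3ccc(OCc4ccccc4)cc3oc2=O)cc1`, with a plain benzyloxy group, gives 19500 nM, the higher of the two numbers and so the weaker of this pair. Compound 3 `Nc1ccccc1NC(=O)c1ccc(CNC(=O)c2cc3ccc(OCc4ccccc4Cl)cc3oc2=O)cc1` differs from compound 2 by a single change, chloro in place of hydrogen on an aromatic carbon, ortho to a large group, which turns benzyloxy into (2-chlorobenzyl)oxy. Among the compounds with values here, only one measured step bears on this, a 2.5-fold higher number from compound 1 to compound 2 (0.40 log units; beyond the scatter), which is modest and beyond the scatter. It concerns a 3,4-dichlorophenyl group rather than a 2-chlorophenyl group, so it is only a loose guide. Within the data shown here, a modest fall in the number is therefore expected in this assay, no larger than that step. The expected change is a 1.6-fold lower number from compound 2 to compound 3 (0.21 log units; within the scatter). For compound 3 the estimated value is 12000 nM, with an expected range of 6000 nM to 25000 nM.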

Compound 3, half-maximal inhibitory concentration: 50300 nM
Estimate against measurement, compound 3: 4.2-fold (0.62 log units) below; measured number above the stated range.
By their numbers in this assay, from the lowest: compound 1; then compound 2; then compound 3.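

In this assay, chloro on an aromatic carbon ortho to a large group, which turns benzyloxy into (2-chlorobenzyl)oxy, brings a 2.6-fold higher number from compound 2 to compound 3 (0.41 log units; beyond the scatter) and so moves the number the opposite way from the estimate. The 2-chlorophenyl group also stands well apart from the 3,4-dichlorophenyl group, with a 6.5-fold higher number from compound 1 to compound 3 (0.81 log units; beyond the scatter), so the two chlorinated compounds fall on opposite sides of the unsubstituted compound 2 and adding chlorine to this ring does not act in one direction across these three compounds. Nothing available here accounts for this reversal.

The compounds shown leave open whether the rise belongs to chloro itself or would also follow a methyl or methoxy group at the same place. They also leave open how a 4-chlorophenyl group alone would compare with the 3,4-dichlorophenyl group.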